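Aryl substitution on the shared core: bromo at the meta position

The source may hold more compounds than are shown below. What is called first, only, known or untested is meant among the compounds shown, and "the series" means these compounds.

Measured so far:
compound 1 `CC1=NC(C)=C(C(=O)O)C(c2ccccc2[N+](=O)[O-])/C1=C(\O)OC/C=C/c1ccccc1` — 31 nM
compound 2 `CC1=NC(C)=C(C(=O)O)C(c2ccccc2)/C1=C(\O)OC/C=C/c1ccccc1` — 9 nM
compound 3 `COC(=O)c1cccc(C2C(C(=O)O)=C(C)N=C(C)/C2=C(/O)OC/C=C/c2ccccc2)c1` — 4400 nM

In a functional assay on thoracic aorta for inhibition of Voltage-gated L-type calcium channel (Rattus norvegicus) (a lower number here means a stronger inhibitor, a higher number a weaker inhibitor), compound 2 gives the lowest number of the three measured compounds; compound 1 comes nearest, compound 3 lies furthest away, both steps beyond the scatter.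

The new compound 4 `CC1=NC(C)=C(C(=O)O)C(c2cccc(Br)c2)/C1=C(\O)OC/C=C/c1ccccc1` differs from compound 2 by bromo in place of hydrogen on an aromatic carbon; placed meta to a large group, the same difference read one bond further out is phenyl to 3-bromophenyl.

Going by the values given here, two measured steps bear on this. Substituting the aromatic ring at all cost something: a 3.4-fold lower number from compound 1 to compound 2 (0.54 log units; beyond the scatter). Substituting it at the meta position with methoxycarbonyl cost far more: a 490-fold higher number from compound 2 to compound 3 (2.69 log units; beyond the scatter). Bromo is a single heavy atom, smaller than methoxycarbonyl, so the step for compound 4 is expected to lie between these two, an increase in this assay beyond the scatter but well short of the loss seen with compound 3.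

Compound 4 is therefore estimated at 50 nM, with a range of 12 nM to 250 nM, corresponding to an expected step of a 5.6-fold higher number from compound 2 to compound 4 (0.74 log units; beyond the scatter).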

Compound 4, half-maximal inhibitory concentration: 10 nM
Compound 4: the middle estimate sits 5.0-fold (0.70 log units) above what was measured, and the stated range ends above it.
By their numbers in this assay, from the lowest: compounds 2 and 4 (each within the scatter of the next); then compound 1; then compound 3.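

Working notes: in this assay, a bromo group meta to a large group is tolerated on this aromatic ring, with a 1.1-fold higher number from compound 2 to compound 4 (0.05 log units; within the scatter). The heavy loss seen with methoxycarbonyl is therefore not a cost of every substituent at this place, as the exchange of that group for bromo gives a 440-fold lower number from compound 3 to compound 4 (2.64 log units; beyond the scatter). The 3-bromophenyl group also compares well with 2-nitrophenyl on the saturated ring carbon, with a 3.1-fold lower number from compound 1 to compound 4 (0.49 log units; beyond the scatter).

No available evidence accounts for the sharp difference between bromo and methoxycarbonyl at this place. As far as these compounds go, it remains open where the loss begins between these two groups, and how an amine, a carboxylic acid or a longer alkyl chain would read at this place.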